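The source may report more compounds than this note shows. Statements on the series, on what has been measured and on what is new or still open speak of the compounds shown alone.

Compound 1 `C=Cc1nc2ccccc2s1` gives > 40000 nM in a functional assay on HCT-116 cells (Homo sapiens) for cytotoxicity, with a stated time of 3 days (on this read-out higher numbers stand for weaker inhibition and lower numbers for stronger inhibition), a limit of the assay rather than a number. Compound 2 `Brc1nc2ccccc2o1` gives > 40000 nM in this assay, again a limit. Compound 3 `C=Cc1nc(C(=O)OCC)cs1` gives > 40000 nM in this assay, also a limit.

Compound 1 therefore stands nowhere in particular among the numbers shown: for it, as for compound 2 and compound 3, only a limit is known, since (the limit of > 40000 nM in this assay, at which 3 of the 3 values shown sit). Among the measured compounds shown here, no ranking of the three is possible, and no step between measured compounds is available from which a trend could be read.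

The piece follows compound 1 to compound 4 `C#Cc1nc2ccccc2s1`. The change is ethynyl in place of vinyl on an aromatic carbon. With every measured value sitting at the same limit, there is nothing in the shown data that separates one compound from another, and nothing that points to a gain of potency from the exchange of vinyl for ethynyl.

The expected step in this assay is a step that the limit leaves unreadable from compound 1 to compound 4, which amounts to none beyond the scatter; compound 4 is expected to remain at or near the limit. The estimate for compound 4 in this assay is 60000 nM, with a range from 20000 nM to 200000 nM, and most likely the assay will again report only a limit.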

Compound 4, half-maximal inhibitory concentration: 19600 nM
Beside the measured number, compound 4's estimate is 3.1-fold (0.49 log units) above it, outside the stated range (below it).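

Among the compounds shown here, compound 4 is the first compound here for which this assay returns a number rather than a limit, so the position on an aromatic carbon of the five-membered aromatic ring, next to the ring nitrogen and next to the ring sulfur, is no longer known from limits alone. For compound 1 the value > 40000 nM is a limit of the assay. Ethynyl in place of vinyl on this carbon, a triple bond outside the aromatic rings for a double bond, gives an at least 2.0-fold lower number from compound 1 to compound 4 (0.30 log units; that floor lies within the scatter), and that figure is only a floor, with the true size of the step unknown: the limit of > 40000 nM in this assay, at which 3 of the 4 values shown sit.

Going by these compounds, what a nitrile, an amine or a longer chain on this same carbon would give in this assay stays open, and so does whether any such group would go further than ethynyl. Also open, on these data alone, is whether ethynyl in place of vinyl on the core of compound 3 would likewise yield a number rather than a limit, and the steps involving compound 2 and compound 3 cannot be read.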